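The compounds below may be only part of what the source reports. "The series", "measured", "known", "first", "only" and "open" are said of these compounds alone.

Measured so far in a functional assay on HEp-2 cells (Homo sapiens) for antiproliferative activity, read by MTT assay, with a stated time of 72 h; a lower number here means a stronger inhibitor, a higher number a weaker inhibitor:
compound 1 `O=c1cc(CSC(=S)N2CCCCC2)oc2cc(Cl)ccc12` gives 1600 nM
compound 2 `COc1ccc2oc(CSC(=S)N(C(C)C)C(C)C)cc(=O)c2c1` gives 7600 nM
compound 3 `CC(C)N(C(=S)SCc1cc(=O)c2ccc(Cl)cc2o1)C(C)C` gives 22700 nM

Compound 3 and compound 1 share a core and differ in one place: piperidin-1-yl in place of diisopropylamino on a thiocarbonyl carbon. This single change gives a 14-fold lower number from compound 3 to compound 1 (1.15 log units; beyond the scatter). Compound 2 stands between the two in this assay, second highest of the three numbers: against compound 3 it reads lower, against compound 1 higher. The difference between the core of compound 2 and the core of compound 3 is not broken down here.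

Compound 4 `COc1ccc2oc(CSC(=S)N3CCCCC3)cc(=O)c2c1` has not yet been measured. Relative to compound 2 it carries the following change: piperidin-1-yl in place of diisopropylamino on a thiocarbonyl carbon. Its place is described in the same words as for the pair compound 3 to compound 1, so this is the same change, now made on the core of compound 2. Going by the values given here, the only precedent is the one measured step, and a single pair carries no information on how well that step transfers onto a different core. The expected step is a 9.5-fold lower number from compound 2 to compound 4 (0.98 log units; beyond the scatter), kept somewhat short of the measured one because the gain from a 14-fold lower number from compound 3 to compound 1 (1.15 log units; beyond the scatter) rests on one pair only. Compound 4 is accordingly estimated at 800 nM in this assay, with a range from 250 nM to 2600 nM.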

Compound 4, half-maximal inhibitory concentration: 1500 nM
Estimate against measurement, compound 4: 1.9-fold (0.27 log units) below; the measured number falls inside the stated range.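

In this assay, piperidin-1-yl in place of diisopropylamino on a thiocarbonyl carbon lowers the number again on the second core, with a 5.1-fold lower number from compound 2 to compound 4 (0.70 log units; beyond the scatter), so the direction of the change carries over in both pairs shown. The size of the step does not carry over unchanged, and a gain read on one core cannot be applied in full to the other: the same change on two cores in this assay, a 14-fold lower number (1.15 log units; beyond the scatter) from compound 3 to compound 1 and a 5.1-fold lower number (0.70 log units; beyond the scatter) from compound 2 to compound 4, 2.8-fold (0.45 log units) apart, beyond the scatter of two such steps

Two pairs show neither which feature of the cores accounts for this gap nor how large the step would be on a third core, so the series supports a shared direction but no fixed increment.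

The compounds shown hold only diisopropylamino and piperidin-1-yl on the thiocarbonyl carbon, leaving open how a morpholin-4-yl, pyrrolidin-1-yl or dimethylamino group would compare on either core. From the compounds shown here alone, the cores carry only chloro or methoxy, so it also remains open whether the direction of the step would hold on a core bearing fluoro or nitrile, or on one with no such substituent at all.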